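The source may report more compounds than this note shows. Statements on the series, on what has been measured and on what is new or still open speak of the compounds shown alone.

Measured so far:
compound 1, `CCCn1c(=O)[nH]c2nc(-c3ccc(S(=O)(=O)N4CCN(c5ccc(F)cc5)CC4)cc3)[nH]c2c1=O` — 38%
compound 2, `CCCn1c(=O)[nH]c2nc(-c3ccc(S(=O)(=O)N4CCN(c5ccc(Br)cc5)CC4)cc3)[nH]c2c1=O` — 29%
compound 3, `CCCn1c(=O)[nH]c2nc(-c3ccc(S(=O)(=O)N4CCN(c5ccccc5)CC4)cc3)[nH]c2c1=O` — 27%

In an assay on CHO cells for displacement of a labelled ligand from adenosine receptor A3 (Homo sapiens), read by scintillation counting, with a stated time of 45 min, tested at 1 uM, in the presence of a further agent that is not named here (a higher number here means more inhibition at the concentration tested (going by the name of the read-out), a lower number less inhibition), compound 3 gives the lowest of the three numbers; its nearest neighbour is compound 2, and the gap a number 2 percentage points lower from compound 2 to compound 3 (within the scatter) is within the scatter, while the gap to compound 1, a number 11 percentage points lower from compound 1 to compound 3 (beyond the scatter), is beyond it, though modest.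

Compound 4, `CCCn1c(=O)[nH]c2nc(-c3ccc(S(=O)(=O)N4CCN(c5ccccc5Cl)CC4)cc3)[nH]c2c1=O`, has not yet been measured. It differs from compound 3 by chloro in place of hydrogen on an aromatic carbon.

Within the data shown here, two measured steps bear on it, both removing a halogen from the same ring: a number 11 percentage points lower from compound 1 to compound 3 (beyond the scatter) and a number 2 percentage points lower from compound 2 to compound 3 (within the scatter). Read in reverse, adding a halogen gave a small rise at most, and one of the two additions lay within the scatter. Among the measured compounds shown here, no measured step introduces chloro, and none places a group ortho to a large group, so the analogy is loose. A small upward step, a number 6 percentage points higher from compound 3 to compound 4 (within the scatter), is therefore expected, of a size that may well fall within the scatter.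

For compound 4 the estimate in this assay is 33%, with a range of 20% to 46%.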

Compound 4, a percentage reported as inhibition, at one concentration (the size of the read-out at that concentration, not a potency): 32%
Compound 4: the middle estimate sits 1 percentage points above what was measured; low and high end bracket the measured number.
By their numbers in this assay, from the lowest: compounds 3, 2, 4 and 1 (each within the scatter of the next, the first and the last beyond it).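

In this assay, among these compounds, the change from phenyl to 2-chlorophenyl puts a halogen ortho to a large group for the first time, and it gives a number 5 percentage points higher from compound 3 to compound 4 (within the scatter), so chloro at this place is not told apart from hydrogen. The steps of a number 3 percentage points higher from compound 2 to compound 4 (within the scatter) and a number 6 percentage points lower from compound 1 to compound 4 (within the scatter) also stay within the scatter, although each changes both the halogen and its place on the ring, so neither change can be read on its own. No measurement at hand explains these small steps.

Still open, as far as these compounds go, is whether an amine or a carboxylic acid at this place on the ring would give a step beyond the scatter. These single-concentration readings also leave the potency of compound 4 open.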